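This account rests on a few compounds, and the source may have more. Where it says the series, first, only, none or still open, it means among the compounds named here.

Measured compounds:
Compound 1 `COc1cc(O)c(C(=O)/C=C/c2ccccc2)cc1I`: > 50000 nM
Compound 2 `CCCOc1ccc(C(=O)/C=C/c2ccccc2)c(O)c1`: > 50000 nM

Both compounds were tested in a functional assay on MCF7 cells (Homo sapiens) for antiproliferative activity, with a stated time of 48 h; on this read-out lower numbers stand for stronger inhibition and higher numbers for weaker inhibition. In this assay, compound 1 gives > 50000 nM, which is a limit of the assay and not a number. Compound 2 gives > 50000 nM, which is likewise a limit. Compound 1 therefore stands at the limit of > 50000 nM in this assay, at which 2 of the 2 values shown sit, and no exact value places it.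

Compound 3 `COc1cc(O)c(C(=O)/C=C/c2ccccc2)cc1Br` has not yet been measured. It keeps the core of compound 1 and carries bromo in place of iodo on an aromatic carbon, ortho to a methoxy group and para to a hydroxy group: bromo in place of iodo on an aromatic carbon.

Among the measured compounds shown here, no measured pair shows what this exchange does, so the only guide is the standing of compound 1 at > 50000 nM. In this assay, no change beyond the scatter is expected, in either direction. The estimated move is a number no higher from compound 1 to compound 3 (the limit leaves the size open), and a result reported only as a limit is considered likely. For compound 3, the expected value is 50000 nM, within an estimated range of 20000 nM to 100000 nM.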

Compound 3, half-maximal inhibitory concentration: > 50000 nM
Compound 3 ended at the assay's limit; the forecaster's own chance of this, stated with the estimate: 70%; the middle value lies on the limit itself.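

Compound 3, like compound 1, is reported in this assay only as a limit and not as a number, so no step can be read for bromo in place of iodo between these two compounds: the limit of > 50000 nM in this assay, at which 3 of the 3 values shown sit.

The compounds shown leave open where the true value of each lies and whether this exchange changes the read-out at all.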